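Alkoxy variation at the ether position of the shared core

The source may report more compounds than this note shows. Statements on the series, on what has been measured and on what is new or still open speak of the compounds shown alone.

Measured compounds:
compound 1 `CCCCOc1cc(CCc2nc(C)c(CC)s2)nc(NCc2cc(Cl)cc(NC(=O)OC(C)C)c2)c1` gives 16 nM
compound 2 `CCc1sc(CCc2cc(OC3CCC3)cc(NCc3cc(Cl)cc(NC(=O)OC(C)C)c3)n2)nc1C` gives 11 nM
compound 3 `CCc1sc(CCc2cc(OC3CCCCC3)cc(NCc3cc(Cl)cc(NC(=O)OC(C)C)c3)n2)nc1C` gives 29 nM

In an assay on cells for binding affinity to Neuropeptide Y receptor type 1 (Homo sapiens) (on this read-out higher numbers stand for weaker inhibition and lower numbers for stronger inhibition), compound 3 stands at the highest number of the three; compound 1 lies within the scatter of it, compound 2 beyond. The measured steps are a 1.5-fold lower number from compound 1 to compound 2 (0.16 log units; within the scatter), a 1.8-fold higher number from compound 1 to compound 3 (0.26 log units; within the scatter) and a 2.6-fold higher number from compound 2 to compound 3 (0.42 log units; beyond the scatter). Compound 4 `CCc1sc(CCc2cc(OCCc3ccccc3)cc(NCc3cc(Cl)cc(NC(=O)OC(C)C)c3)n2)nc1C` differs from compound 3 by phenethyl in place of cyclohexyl on an oxygen on an aromatic ring. Within the data shown here, no measured step covers phenethyl. The steps among butyl, cyclobutyl and cyclohexyl are small to modest, so for compound 4 no step beyond the scatter in this assay is expected in either direction, the estimate being a 1.0-fold higher number from compound 3 to compound 4 (0.01 log units; within the scatter). Compound 4 is therefore expected near 30 nM, with a range from 12 nM to 75 nM.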

Compound 4, half-maximal inhibitory concentration: 30 nM
Compound 4: the middle estimate sits on the measured number at the digits printed; measured number inside the range.
By their numbers in this assay, from the lowest: compounds 2, 1, 3 and 4 (each within the scatter of the next, the first and the last beyond it).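

In this assay an aromatic ring of carbon only on the oxygen reads the same as the non-aromatic cyclohexyl, with a 1.0-fold higher number from compound 3 to compound 4 (0.01 log units; within the scatter) as the step between them. Phenethyl also stays within the scatter of the open-chain butyl, at a 1.9-fold higher number from compound 1 to compound 4 (0.27 log units; within the scatter) and no further, but it separates modestly from cyclobutyl, with a 2.7-fold higher number from compound 2 to compound 4 (0.44 log units; beyond the scatter) as a step beyond the scatter that matches the one seen for cyclohexyl. No evidence is available that explains these numbers.

The compounds shown leave open how an amine or a carboxylic acid on the chain at this oxygen would read. On these data alone, a chain longer than phenethyl, or a phenyl directly on the oxygen, also remains open.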